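From propanoyl to (4-bromophenyl)carbonyl on the shared core

A few compounds are considered here, and "the series" means these few. Any claim that something is new, unique, unknown or untested is made for them only; others in the source may bear on it.

Measured in a functional assay on HCT-116 cells (Homo sapiens) for antiproliferative activity, read by MTT assay, with a stated time of 72 h; a higher number here means a weaker inhibitor, a lower number a stronger inhibitor:
Compound 1 `CC(=O)N(C)c1ccc2[nH]c(-c3n[nH]c4ccccc34)cc2n1`: 14800 nM
Compound 2 `CCC(=O)N(C)c1ccc2[nH]c(-c3n[nH]c4ccccc34)cc2n1`: 10800 nM

Going by the values given here, compound 2 stands level with compound 1, the only other compound measured, and their two values lie within the scatter of each other. Compound 3 `CN(C(=O)c1ccc(Br)cc1)c1ccc2[nH]c(-c3n[nH]c4ccccc34)cc2n1` departs from compound 2 at a single place, with 4-bromophenyl in place of ethyl on a carbonyl carbon. Among the compounds with values here, one measured step bears on this change. It is a 1.4-fold lower number from compound 1 to compound 2 (0.14 log units; within the scatter), and it came from methyl in place of hydrogen on a saturated chain carbon bound to a carbonyl carbon. Within the data shown here, that step altered the same chain, but it brought in no ring, and no compound with a ring on this carbonyl carbon has been measured. The expectation in this assay is therefore no step beyond the scatter, held with a wide margin in either direction. The estimate amounts to an expected change, a 1.4-fold lower number from compound 2 to compound 3 (0.13 log units; within the scatter). For compound 3 the estimated value is 8000 nM, with an expected range from 2500 nM to 20000 nM.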

Compound 3, half-maximal inhibitory concentration: 6110 nM
For compound 3 the middle estimate is 1.3-fold (0.12 log units) above the measured one; the measured number falls inside the stated range.
By their numbers in this assay, from the lowest: compounds 3, 2 and 1 (each within the scatter of the next, the first and the last beyond it).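

In this assay, going by these compounds alone, the carbonyl carbon now carries a ring for the first time, and the exchange of ethyl for 4-bromophenyl gives a step that stays within the scatter (a 1.8-fold lower number from compound 2 to compound 3 (0.25 log units; within the scatter)), so this position admits an aromatic ring of carbon with a bromine on it without any rise in the number. Within the data shown here, measured from the smaller acyl group of compound 1, the same ring gives the first step in this short series that lies beyond the scatter (a 2.4-fold lower number from compound 1 to compound 3 (0.38 log units; beyond the scatter)), though it is only modest, and all three compounds remain in a similar range. No measurement is available here that would explain either step.

The compounds shown do not separate the contribution of the ring from that of the bromine, so a plain phenyl or a saturated cyclohexyl on this carbonyl carbon would be needed to tell the two apart. They also leave open how this position would respond to a ring bearing an amine or a carboxylic acid, or to a longer chain in place of the ring.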